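Branching a Side Chain: From Compound 1 to Compound 3

The source may report more compounds than this note shows. Statements on the series, on what has been measured and on what is new or still open speak of the compounds shown alone.

Compound 1, `CCCCCO[C@@H]1C=CC(=O)[C@@H](COC(=O)C(C)(C)C)O1`: 7380 nM
Compound 2, `CC(=O)OC[C@H]1O[C@H](OCCC(C)C)C=C([C@H](O)c2ccc([N+](=O)[O-])cc2)C1=O`: 14300 nM

Both values come from an ADME assay on Vero cells (Chlorocebus sabaeus) for cytotoxicity, read by resazurin assay, with a stated time of 24 h; on this read-out lower numbers stand for higher toxicity in this test and higher numbers for lower toxicity in this test. Compound 1 and compound 2 sit within the usual scatter of one another, so neither stands apart on this read-out. Compound 3, `CC(C)CCO[C@@H]1C=CC(=O)[C@@H](COC(=O)C(C)(C)C)O1`, has not been measured. It differs from compound 1 only by isopropyl in place of propyl on a saturated chain carbon, two bonds along the chain from an oxygen on a saturated carbon. Among the measured compounds shown here, no measured pair shows a change of this kind, so nothing here calibrates it. A rearrangement this small is expected to shift this assay little, and the step of a 1.1-fold higher number from compound 1 to compound 3 (0.04 log units; within the scatter) is expected to stay within the scatter. Compound 3 is therefore estimated at 8000 nM, between 3500 nM and 18000 nM.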

Compound 3, half-maximal cytotoxic concentration: 36000 nM
Estimate against measurement, compound 3: 4.5-fold (0.65 log units) below, outside the stated range (above it).
By their numbers in this assay, from the lowest: compounds 1 and 2 (each within the scatter of the next); then compound 3.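

In this assay, isopropyl in place of propyl on a saturated chain carbon, two bonds along the chain from an oxygen on a saturated carbon, gives a 4.9-fold higher number from compound 1 to compound 3 (0.69 log units; beyond the scatter). The two compounds have the same atoms, joined differently, so branching alone at this position can move this read-out beyond the scatter. Nothing shown here gives a reason for the shift. Still open, from the compounds shown here alone, is whether a longer chain, such as hexyl, or a chain ending in an amine would raise the number further or lower it.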